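From a Chlorophenyl Amide to a Thiazolyl Amide

The compounds below may be only part of what the source reports. "The series", "measured", "known", "first", "only" and "open" are said of these compounds alone.

Compound 1 `COCOc1cc(/C=C/C(=O)OCC(=O)Nc2ccc(Cl)cc2)ccc1OCc1ccccc1` was tested in a functional assay on LS174T cells (Homo sapiens) for cytotoxicity, read by MTT assay, with a stated time of 72 h; on this read-out higher numbers stand for weaker inhibition and lower numbers for stronger inhibition. In this assay compound 1 gives > 200000 nM, which is a limit of the assay rather than a number. Compound 2 `COc1ccc(NC(=O)COC(=O)/C=C/c2cc(OC)c(OCc3ccccc3)c(OC)c2)cc1` gives > 200000 nM in this assay, also a limit. Compound 3 `COc1ccc(/C=C/C(=O)OCC(=O)Nc2ccccc2)cc1OC` gives > 200000 nM in this assay, again a limit. All three values shown thus sit at the limit of > 200000 nM in this assay, at which 3 of the 3 values shown sit, so compound 1 stands with its companions at that limit and cannot be ranked against them. Compound 4 `COCOc1cc(/C=C/C(=O)OCC(=O)Nc2nccs2)ccc1OCc1ccccc1` differs from compound 1 by 1,3-thiazol-2-yl in place of 4-chlorophenyl on an amide-type nitrogen. Within the data shown here, no step between two measured compounds is known here. The step from compound 1 to compound 4 in this assay is expected to be a number no higher from compound 1 to compound 4 (the limit leaves the size open), that is, none beyond the scatter. Compound 4 is estimated to give 200000 nM in this assay, within 60000 nM to 500000 nM, with a good chance that only a limit is reported again.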

Compound 4, half-maximal inhibitory concentration: > 200000 nM
Compound 4 ended at the assay's limit; the forecaster's own chance of this, stated with the estimate: 70%; the middle value sits exactly at the limit.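

No step can be read from compound 1 to compound 4 in this assay because both stand at a limit: the limit of > 200000 nM in this assay, at which 4 of the 4 values shown sit. The compounds shown leave open whether 1,3-thiazol-2-yl and 4-chlorophenyl differ at all on this read-out.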